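Swapping phenoxymethyl for 2-hydroxyphenyl on the triazole carbon

This account rests on a few compounds, and the source may have more. Where it says the series, first, only, none or still open, it means among the compounds named here.

Among the measured compounds shown here, compound 2 `O=C(NCc1nn2c(COc3ccccc3)nnc2s1)c1ccccc1` gives 35.9% in a functional assay on the whole organism (strain Wistar) for inhibition, with Rattus norvegicus as the target, read by paw edema, with stated times of 30 min and 2 h, at a dose of 20 mg/kg by the oral route (on this read-out lower numbers stand for less inhibition and higher numbers for more inhibition at the one dose given (going by the name of the read-out)), the higher of the two numbers measured so far; compound 1 `O=C(NCc1nn2c(Cc3ccccc3)nnc2s1)c1ccccc1` gives 21.2%. For the measured compounds named here, the one measured step, a number 14.7 percentage points higher from compound 1 to compound 2 (beyond the scatter), is modest. Compound 3 `O=C(NCc1nn2c(-c3ccccc3O)nnc2s1)c1ccccc1` differs from compound 2 by 2-hydroxyphenyl in place of phenoxymethyl on an aromatic carbon. Going by the values given here, no measured step matches this change, since the step from compound 1 to compound 2 only adds an oxygen to the chain, so no shift beyond the scatter is expected, and a number 4.9 percentage points lower from compound 2 to compound 3 (within the scatter) is the expected step. Compound 3 is therefore estimated at 31%, within 16% to 46%.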

Compound 3, a percentage reported as inhibition, in the whole organism at one dose (the size of the read-out at that dose, not a potency): 24.4%
Estimate against measurement, compound 3: 6.6 percentage points above, and the stated range covers the measured number.
By their numbers in this assay, from the lowest: compounds 1 and 3 (each within the scatter of the next); then compound 2.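

On this aromatic carbon, 2-hydroxyphenyl in place of phenoxymethyl gives a number 11.5 percentage points lower from compound 2 to compound 3 (beyond the scatter) in this assay, so the gain seen with phenoxymethyl does not carry over to this directly attached ring. Against benzyl, 2-hydroxyphenyl gives a number 3.2 percentage points higher from compound 1 to compound 3 (within the scatter), so the hydrogen-bond donor it brings sets it apart from benzyl by no more than the scatter. Going by these compounds, whether an amine, a carboxylic acid or a longer phenoxyalkyl chain on this carbon would give a different number remains open. Nothing available explains why these numbers fall as they do.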